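Thiophene replaces nitrophenyl in a chromene chalcone series

The source may report more compounds than this note shows. Statements on the series, on what has been measured and on what is new or still open speak of the compounds shown alone.

Three chalcones built on one shared core have been tested in a functional assay on K562 cells (Homo sapiens) for antiproliferative activity, read by MTT assay, with a stated time of 24 h; on this read-out lower numbers stand for stronger inhibition and higher numbers for weaker inhibition. Compound 1 `COc1ccc(C(=O)/C=C/c2ccc(-c3ccccc3)cc2)c2c1C=CC(C)(C)O2` carries a phenyl on the aromatic carbon; in this assay compound 1 gives > 10000 nM, which is a limit of the assay and not a number. Compound 3 `COc1ccc(C(=O)/C=C/c2ccc(C(F)(F)F)cc2)c2c1C=CC(C)(C)O2` carries a trifluoromethyl there, and in this assay compound 3 also gives > 10000 nM, again a limit rather than a number. Going by the values given here, compound 2 `COc1ccc(C(=O)/C=C/c2ccc([N+](=O)[O-])cc2)c2c1C=CC(C)(C)O2`, with a nitro on that aromatic carbon, gives 7770 nM in this assay, the only true number among the three results; the steps of an at least 1.2-fold lower number from compound 1 to compound 2 (0.10 log units; that floor lies within the scatter) and an at least 1.2-fold higher number from compound 2 to compound 3 (0.10 log units; that floor lies within the scatter) both have floors within the scatter, and the limit of > 10000 nM in this assay, at which 2 of the 3 values shown sit, leaves their sizes unreadable.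

Compound 4 `COc1ccc(C(=O)/C=C/c2cccs2)c2c1C=CC(C)(C)O2` differs from compound 2 by thiophen-2-yl in place of 4-nitrophenyl on a double-bonded chain carbon bound to a double-bonded chain carbon. Among the compounds with values here, no measured step changes the ring attached to the chain carbon itself, so none bears directly on this move. Given that every measured compound sits at or near the limit, compound 4 is expected to remain weak, with a step of a 1.2-fold higher number from compound 2 to compound 4 (0.06 log units; within the scatter). The estimate for compound 4 in this assay is 9000 nM, within 3000 nM to 25000 nM.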

Compound 4, half-maximal inhibitory concentration: > 10000 nM
Compound 4: a limit, no number; the forecaster's own chance of this, stated with the estimate: 50%; at least 1.1-fold (0.04 log units) between middle value and limit.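

Thiophen-2-yl in place of 4-nitrophenyl is the first change here of the whole ring on the chain carbon, rather than of a group on that ring, and it gives an at least 1.2-fold higher number from compound 2 to compound 4 (0.10 log units; that floor lies within the scatter). In this assay compound 4 gives > 10000 nM, which is a limit of the assay and not a number. The true size of this step, like any comparison of compound 4 with compound 1 or compound 3, cannot be read because of where the values sit: the limit of > 10000 nM in this assay, at which 3 of the 4 values shown sit.

The compounds shown leave open whether any ring on this chain carbon can give a value well clear of that limit. How an aminophenyl, a carboxyphenyl or a furan-2-yl there would read in this assay remains an open question.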